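The source may hold more compounds than are shown below. What is called first, only, known or untested is meant among the compounds shown, and "the series" means these compounds.

Working notes on the series, read in a functional assay on the whole organism (stomach) for inhibition, with Rattus norvegicus as the target; a lower number here means that less compound is needed, a higher number that more compound is needed for the effect. Of the compounds shown here, two have numbers so far. Compound 1 `CN(c1ccccc1)c1nc(N(C)c2ccccc2)c2ccccc2n1` gives 2.81 umol/kg. Compound 2 `Cc1ccccc1Nc1nc(N)nc2ccccc12` gives 48 umol/kg, the higher of the two numbers and beyond the usual scatter of compound 1. Within the data shown here, no two measured compounds differ in one place only, so this gap cannot be assigned to any single change.

Compound 3 `COc1cccc2c(Nc3ccccc3C)nc(N)nc12` is still to be measured. It follows from compound 2 with methoxy in place of hydrogen on an aromatic carbon.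

Among the measured compounds shown here, no measured step covers this change, so the expectation in this assay is weakly anchored. The only guide is that compound 1 at 2.81 umol/kg shows that numbers well under that of compound 2 occur among these compounds. A moderate fall in the number is expected, probably just beyond the scatter, although no change beyond the scatter remains possible. The expected step is a 3.0-fold lower number from compound 2 to compound 3 (0.48 log units; beyond the scatter). For compound 3 the estimated value is 16 umol/kg, with an expected range of 4 umol/kg to 55 umol/kg.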

Compound 3, dose for half-maximal effect: 7.11 umol/kg
Estimate against measurement, compound 3: 2.3-fold (0.35 log units) above; the measured number falls inside the stated range.
By their numbers in this assay, from the lowest: compound 1; then compound 3; then compound 2.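

In this assay, among these compounds, methoxy in place of hydrogen on an aromatic carbon, ortho to a fused ring and meta to a fused ring, gives a 6.8-fold lower number from compound 2 to compound 3 (0.83 log units; beyond the scatter), the first change that can be read on its own. This carbon of the shared core therefore accepts a group of 2 heavy atoms, and the number falls rather than rises, which the gap between compound 1 and compound 2 could not show. The data give the size and direction of this step, but nothing at hand bears on the reason for it.

On these data alone, it remains open whether a step of like size would follow from a hydroxyl, an ethoxy or a chlorine on this same carbon, or from methoxy on the other carbons of that ring, so one step cannot separate an effect of methoxy itself from an effect of substitution at this place. As far as these compounds go, it is also open whether methoxy would lower the number on the core of compound 1, which differs from compound 2 and compound 3 in more than one place, so those gaps cannot be read as steps.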